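A fluoro for methyl swap on the pendant ring

A few compounds are considered here, and "the series" means these few. Any claim that something is new, unique, unknown or untested is made for them only; others in the source may bear on it.

Compound 3 `Cc1ccc(Cn2c(CN3CCN(C(=O)C4CC4)CC3)nc3ccccc32)cc1` gives 51.5% in an assay on isolated protein for inhibition of aldehyde dehydrogenase 1A1 (Homo sapiens), read by spectrophotometry, tested at 10 uM (a lower number here means less inhibition, a higher number more inhibition at the concentration tested (going by the name of the read-out)), the second highest of three numbers; compound 2 `O=C(C1CC1)N1CCN(Cc2nc3ccccc3n2Cc2ccccc2C(F)(F)F)CC1` gives 56.3%, within the scatter of it, while compound 1 `CCn1c(CN2CCN(C(=O)C3CC3)CC2)nc2ccccc21` gives 20.8%, far below. Compound 4 `O=C(C1CC1)N1CCN(Cc2nc3ccccc3n2Cc2ccc(F)cc2)CC1` differs from compound 3 by fluoro in place of methyl on an aromatic carbon, on the ring where the steps of a number 30.7 percentage points higher from compound 1 to compound 3 (beyond the scatter) and a number 4.8 percentage points lower from compound 2 to compound 3 (within the scatter) already bear: the first shows that adding the ring matters greatly, the second that exchanging its substituent stayed within the scatter. Among the compounds with values here, since no measured compound carries a fluoro on this ring, the expectation rests on that second step: compound 4 is expected to show a number 1.5 percentage points lower from compound 3 to compound 4 (within the scatter), and its estimated value is 50%, with a range from 35% to 65%.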

Compound 4, a percentage reported as inhibition, at one concentration (the size of the read-out at that concentration, not a potency): 32.7%
Compound 4: the middle estimate sits 17.3 percentage points above what was measured; the whole stated range lies above it.
By their numbers in this assay, from the lowest: compound 1; then compound 4; then compounds 3 and 2 (each within the scatter of the next).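

Fluoro in place of methyl gives a number 18.8 percentage points lower from compound 3 to compound 4 (beyond the scatter) in this assay and so shows that this ring's substituent can matter, which the earlier exchange within the scatter did not reveal. The 4-fluorophenyl ring also gives a number 23.6 percentage points lower from compound 2 to compound 4 (beyond the scatter) against the 2-(trifluoromethyl)phenyl ring, yet still gives a number 11.9 percentage points higher from compound 1 to compound 4 (beyond the scatter) against methyl on the chain. No supporting measurement is available to explain these differences.

As far as these compounds go, whether a chloro, methoxy or amino group in the same place would read nearer to methyl or to fluoro stays open. So does how fluoro would read elsewhere on this ring.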